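Chloro substitution on two pyrazole cores: notes

The source may hold more compounds than are shown below. What is called first, only, known or untested is meant among the compounds shown, and "the series" means these compounds.

Compound 1 `COc1ccc(OC)c(-c2cc(-c3ccccc3)nn2-c2ccc(S(=O)(=O)NC(C)=O)cc2)c1` and compound 2 `COc1ccc(OC)c(-c2cc(-c3ccc(Cl)cc3)nn2-c2ccc(S(=O)(=O)NC(C)=O)cc2)c1` share one core; in a functional assay on cells (Cancer cell lines, Homo sapiens) for cytotoxicity, read by sulforhodamine B assay, with a stated time of 48 h (on this read-out higher numbers stand for weaker inhibition of growth and lower numbers for stronger inhibition of growth), compound 1 gives 13300 nM and compound 2 gives 17700 nM. The change between them is chloro in place of hydrogen on an aromatic carbon, and the step it made is a 1.3-fold higher number from compound 1 to compound 2 (0.12 log units; within the scatter).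

Compound 3 `Oc1ccc(O)c(-c2cc(-c3ccccc3)nn2-c2ccccc2)c1` carries a different core; how its core differs from that of compound 1 is not broken down here. In this assay compound 3 gives 22600 nM. Compound 4 `Oc1ccc(O)c(-c2cc(-c3ccc(Cl)cc3)nn2-c2ccccc2)c1` is not yet measured and differs from compound 3 by chloro in place of hydrogen on an aromatic carbon. For the measured compounds named here, the change is the same as the one from compound 1 to compound 2: the place is described in identical terms, para to a large group on a six-membered aromatic ring of carbon only, and the same difference cut one bond further out reads phenyl to 4-chlorophenyl in both cases.

Going by the values given here, for compound 4 the expected step in this assay is a 1.2-fold higher number from compound 3 to compound 4 (0.09 log units; within the scatter), resting on the single earlier step of a 1.3-fold higher number from compound 1 to compound 2 (0.12 log units; within the scatter), which stayed within the scatter. Compound 4 is therefore estimated at 28000 nM, with an expected span from 14000 nM to 56000 nM.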

Compound 4, concentration for 50% growth inhibition: 8860 nM
Compound 4: the middle estimate sits 3.2-fold (0.50 log units) above what was measured, and the stated range ends above it.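

In this assay, chloro in place of hydrogen on an aromatic carbon gives a 2.6-fold lower number from compound 3 to compound 4 (0.41 log units; beyond the scatter), a modest step in size but one that stands clear of the usual variation on the core of compound 3. Set beside the earlier step, this shows that the change does not carry over with the same outcome between these two cores: the same change on two cores in this assay, a 1.3-fold higher number (0.12 log units; within the scatter) from compound 1 to compound 2 and a 2.6-fold lower number (0.41 log units; beyond the scatter) from compound 3 to compound 4, 3.4-fold (0.53 log units) apart, beyond the scatter of two such steps It does not show which feature of the cores sets the two steps apart, nor how the change would behave on any further core, as each core here supplies a single step.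

Still open is whether the gap follows the hydroxy groups in place of the methoxy groups or the acetylated sulfonamide, as the compounds shown do not separate these two features. Also open, on these data alone, is how a bromo group, a nitrile or a carboxylic acid in place of the chloro would read on either core.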